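Halogen swap on the aryl piperazine of a thiophene series

The compounds below may be only part of what the source reports. "The series", "measured", "known", "first", "only" and "open" are said of these compounds alone.

Compound 2 `Nc1scc(CN2CCN(c3cc(F)ccc3F)CC2)c1C(=O)c1ccc(Cl)cc1` is tested in an assay on CHO cells for displacement of a labelled ligand from adenosine receptor A1 (Homo sapiens), read by scintillation counting, with a stated time of 120 min, tested at 10 uM (a higher number here means more inhibition at the concentration tested (going by the name of the read-out), a lower number less inhibition), where compound 2 gives 1%. Its closest neighbour is compound 1 `Nc1scc(CN2CCN(c3ccc(F)cc3F)CC2)c1C(=O)c1ccc(Cl)cc1`, which in this assay gives 1%; the step from one to the other is no change at the digits printed from compound 1 to compound 2 (within the scatter), so compound 2 stands level with compound 1 at the digits shown, and both show little inhibition at the concentration tested.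

Compound 3 `Nc1scc(CN2CCN(c3ccc(F)c(Cl)c3)CC2)c1C(=O)c1ccc(Cl)cc1` is not yet measured. It differs from compound 2 by 3-chloro-4-fluorophenyl in place of 2,5-difluorophenyl on an amine nitrogen in a ring. Within the data shown here, the only step that bears on this change is the one from compound 1 to compound 2, which also rearranges fluorine on the same aryl ring and was no change at the digits printed from compound 1 to compound 2 (within the scatter). Among the measured compounds shown here, no step with a chlorine on that ring is available, so the expectation rests on the single observed move alone.

On that basis compound 3 is expected to remain low, with an estimated step of a number 2 percentage points higher from compound 2 to compound 3 (within the scatter) in this assay, which is no change beyond the scatter. Compound 3 is therefore estimated at 3%, expected to lie between 0% and 15%.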

Compound 3, a percentage reported as inhibition, at one concentration (the size of the read-out at that concentration, not a potency): 0%
Compound 3: middle estimate off by 3 percentage points, on the high side; the range from low to high includes it.
By their numbers in this assay, from the lowest: compounds 3, 1 and 2 (each within the scatter of the next).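

In this assay the change to 3-chloro-4-fluorophenyl on the amine nitrogen in the ring is a number 1 percentage points lower from compound 2 to compound 3 (within the scatter) and, set against the other difluorophenyl group, a number 1 percentage points lower from compound 1 to compound 3 (within the scatter) so the two steps agree with the earlier fluorine shift. Among these compounds, until now this position had been seen only with two fluorines moved around the ring, whereas these steps show that exchanging one fluorine for a chlorine, with the substitution placed differently as well, also leaves the read-out where it was. All three compounds thus stand level within the scatter at little inhibition, and nothing available offers an explanation for this flat result.

The compounds shown carry only halogens on this aryl ring, so they leave open whether a methoxy group, an amine or a carboxylic acid there would give a different reading. They also leave open whether a longer chain in place of the aryl ring on that amine nitrogen, or a change elsewhere on the shared core, would lift the inhibition at all.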